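The source may hold more compounds than are shown below. What is called first, only, known or untested is meant among the compounds shown, and "the series" means these compounds.

Measured compounds:
compound 1, `COc1ccc(-c2cc(/C=C/C(=O)c3ccc(N)cc3)[nH]n2)cc1`: -3%
compound 2, `COc1cc(-c2cc(/C=C/C(=O)c3ccc(N)cc3)[nH]n2)cc(OC)c1OC`: -95%

Both were tested in a functional assay on SK-MEL-5 cells (Homo sapiens) for cytotoxicity, read by sulforhodamine B assay, with a stated time of 48 h, tested at 10 uM; a lower number here means a stronger effect, a higher number a weaker effect of the compound at the concentration tested. Compound 1 gives -3%, while compound 2 gives -95%. Compound 2 thus stands lowest of the two numbers, and its nearest neighbour, compound 1, sits a distance above it that lies beyond the usual scatter of this assay.

The next compound is compound 3, `COc1ccc(-c2cc(/C=C/C(=O)c3ccc(N)cc3)[nH]n2)cc1OC`. It differs from compound 2 by hydrogen in place of methoxy on an aromatic carbon: a methoxy group leaves and a hydrogen atom enters, on an aromatic carbon of a six-membered aromatic ring of carbon only, ortho to a methoxy group and meta to another methoxy group. Going by the values given here, no step between two measured compounds of this kind has been recorded, so the expected size of the change in this assay rests only on the gap between compound 1 and compound 2. Since compound 3 sits structurally between the two, an upward step from compound 2 is expected, a number 50 percentage points higher from compound 2 to compound 3 (beyond the scatter), large enough to exceed the scatter. Compound 3 is therefore estimated at -45%, within a range from -85% to -5%.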

Compound 3, a percentage reported as activity, at one concentration (the size of the read-out at that concentration, not a potency): 6%
The estimate for compound 3 lay 51 percentage points below the measured number; measured number above the stated range.
By their numbers in this assay, from the lowest: compound 2; then compounds 1 and 3 (each within the scatter of the next).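

In this assay, the loss of one methoxy group, from an aromatic carbon ortho to a methoxy group and meta to another methoxy group, gives a number 101 percentage points higher from compound 2 to compound 3 (beyond the scatter), so the strong read-out of compound 2 depends on the methoxy group at this position in the presence of the other two. The methoxy group that separates the other pair gives a number 9 percentage points higher from compound 1 to compound 3 (within the scatter), so a methoxy in place of hydrogen on an aromatic carbon can matter greatly in one setting and not be detectable in another, and the effect of this change cannot be read apart from the methoxy groups already on the ring. Nothing available here speaks to why this one group makes so large a difference.

The compounds shown leave open whether the effect belongs to methoxy itself or would persist with a hydroxyl, an ethoxy, a fluorine or an amine at this position. They also leave open whether removing either of the other two methoxy groups from compound 2 alone would cost as much, or whether all three are needed together.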